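Thioether side-chain replacements on the shared core

The source may hold more compounds than are shown below. What is called first, only, known or untested is meant among the compounds shown, and "the series" means these compounds.

Compound 1 `CC(C)c1n[nH]c2c(NCc3ccc(-c4ccccn4)cc3)nc(SC[C@H](O)CN)nc12` is the best of the three measured compounds in a functional assay on HT cells (Homo sapiens) for antiproliferative activity, read by fluorescence, with a stated time of 72 h (on this read-out lower numbers stand for stronger inhibition of growth and higher numbers for weaker inhibition of growth), where compound 1 gives 63 nM. Compound 2 `CC(C)c1n[nH]c2c(NCc3ccc(-c4ccccn4)cc3)nc(SCC(N)CN)nc12` gives 480 nM and compound 3 `C=CCSc1nc(NCc2ccc(-c3ccccn3)cc2)c2[nH]nc(C(C)C)c2n1` gives 1010 nM. The step to compound 2 is a 7.6-fold higher number from compound 1 to compound 2 (0.88 log units; beyond the scatter), the step to compound 3 is a 16-fold higher number from compound 1 to compound 3 (1.20 log units; beyond the scatter), and between the two, a 2.1-fold higher number from compound 2 to compound 3 (0.32 log units; beyond the scatter).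

Compound 4 `COCSc1nc(NCc2ccc(-c3ccccn3)cc2)c2[nH]nc(C(C)C)c2n1` differs from compound 1 as follows: methoxy in place of 2-amino-1-hydroxyethyl on a saturated chain carbon bound to a sulfur. For the measured compounds named here, the methoxy of compound 4, like the vinyl of compound 3, lacks the donors of the 2-amino-1-hydroxyethyl, so the nearest precedent is a 16-fold higher number from compound 1 to compound 3 (1.20 log units; beyond the scatter); a 7.6-fold higher number from compound 1 to compound 2 (0.88 log units; beyond the scatter) shows that even retaining an amine while losing the hydroxyl costs potency. A large rise in the growth-inhibition number is therefore expected, of about a 14-fold higher number from compound 1 to compound 4 (1.15 log units; beyond the scatter). Compound 4 is estimated at 900 nM, within a range of 300 nM to 3000 nM, in this assay.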

Compound 4, concentration for 50% growth inhibition: 340 nM
The estimate for compound 4 lay 2.6-fold (0.42 log units) above the measured number; measured number inside the range.
By their numbers in this assay, from the lowest: compound 1; then compounds 4 and 2 (each within the scatter of the next); then compound 3.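

In this assay the loss on replacing 2-amino-1-hydroxyethyl with methoxy is a 5.4-fold higher number from compound 1 to compound 4 (0.73 log units; beyond the scatter) and, with compound 3 as the comparison, a 3.0-fold lower number from compound 3 to compound 4 (0.47 log units; beyond the scatter) shows that two replacements lacking those donors are not interchangeable at this place. The step of a 1.4-fold lower number from compound 2 to compound 4 (0.15 log units; within the scatter) places methoxy level with 1,2-diaminoethyl, so retaining amine nitrogen on this chain gives no measurable gain over methoxy, while compound 1 remains separated from every other compound beyond the scatter. No measured evidence here accounts for these differences.

From the compounds shown here alone, how a 2-hydroxyethyl or a 2-aminoethyl on a saturated chain carbon bound to a sulfur would compare with compound 1 remains open, so the separate contributions of the hydroxyl and the amine are unresolved. Going by these compounds, the mirror-image form of the 2-amino-1-hydroxyethyl chain also remains open.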